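Trading phenoxymethyl for 2-phenylethenyl on a glutamyl cap

A few compounds are considered here, and "the series" means these few. Any claim that something is new, unique, unknown or untested is made for them only; others in the source may bear on it.

Compound 3, `CCCCOC(=O)CNC(=O)[C@H](CSc1ccc([N+](=O)[O-])cc1[N+](=O)[O-])NC(=O)CC[C@H](NC(=O)COc1ccccc1)C(=O)OCCCC`, is a protected dipeptide whose thioether carries a dinitrophenyl group and whose terminal amine is capped by a phenoxymethyl carbonyl. In a toxicity assay on KB cells (Homo sapiens) for cytotoxicity, read by fluorescence, with a stated time of 3 days (a lower number here means that less compound is needed, a higher number that more compound is needed for the effect), compound 3 gives only a limit, > 300 uM, and not a measured number. Two close relatives have been tested in the same way. Compound 1, `CCCCOC(=O)CNC(=O)[C@H](CSc1ccc([N+](=O)[O-])cc1[N+](=O)[O-])NC(=O)CC[C@H](NC(=O)CCc1ccccc1)C(=O)OCCCC`, carries a phenethyl cap instead; in this assay compound 1 also reaches only the limit > 300 uM. Compound 2, `CCCCOC(=O)CNC(=O)[C@H](CSc1ccc([N+](=O)[O-])cc1[N+](=O)[O-])NC(=O)CC[C@H](NC(=O)OC)C(=O)OCCCC`, carries a methoxy cap; in this assay compound 2 likewise stops at the limit > 300 uM. Because (the limit of > 300 uM in this assay, at which 3 of the 3 values shown sit), none of the three steps among them can be read: a step that the two limits leave unreadable from compound 1 to compound 2, a step that the two limits leave unreadable from compound 1 to compound 3 and a step that the two limits leave unreadable from compound 2 to compound 3 are all hidden behind the same limit.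

The next compound, compound 4, `CCCCOC(=O)CNC(=O)[C@H](CSc1ccc([N+](=O)[O-])cc1[N+](=O)[O-])NC(=O)CC[C@H](NC(=O)/C=C/c1ccccc1)C(=O)OCCCC`, differs from compound 3 in one place: 2-phenylethenyl in place of phenoxymethyl on a carbonyl carbon. Every cap tried so far has left the cells untouched up to the limit, so the change is expected to stay within scatter, a step that the limit leaves unreadable from compound 3 to compound 4. The estimated result for compound 4 in this assay is 400 uM, with a plausible range from 150 uM to 1500 uM, most likely reported again as a limit.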

Compound 4, concentration for half-maximal effect: 34.4 uM
Compound 4: middle estimate off by 12-fold (1.07 log units), on the high side; the whole stated range lies above it.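

Within the data shown here, this position on the carbonyl carbon can clearly affect the result in this assay: putting 2-phenylethenyl in place of phenoxymethyl gives an at least 8.7-fold lower number from compound 3 to compound 4 (0.94 log units; beyond the scatter), the first readable step in this small series. The same group in place of methoxy gives an at least 8.7-fold lower number from compound 2 to compound 4 (0.94 log units; beyond the scatter), and in place of phenethyl it gives an at least 8.7-fold lower number from compound 1 to compound 4 (0.94 log units; beyond the scatter), so a six-membered aromatic ring in the cap is not enough on its own, since compound 1 and compound 3 also carry one and give no measured number. Each of these steps is only a minimum, and the steps among compound 1, compound 2 and compound 3 cannot be read at all, because those compounds stop at a limit of the assay: the limit of > 300 uM in this assay, at which 3 of the 4 values shown sit.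

The compounds shown do not separate the part played by the double bond from that of the aromatic ring it carries, so a propenyl cap, with the double bond but no ring, or a phenylethynyl cap, with a triple bond in its place, would be informative. They also leave open whether compound 4 would keep its number if the dinitrophenyl group on the thioether were replaced by a plain phenyl group.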